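Compound 3 to Compound 4: Changing the Amide Nitrogen Group

The compounds below may be only part of what the source reports. "The series", "measured", "known", "first", "only" and "open" are said of these compounds alone.

Of the compounds shown here, three sharing one core have been measured in a functional assay on HepG2 cells (Homo sapiens) for antiproliferative activity, read by CCK-8 assay, with a stated time of 48 h; on this read-out lower numbers stand for stronger inhibition and higher numbers for weaker inhibition. Compound 1 `O=C(Nc1ccccc1)c1cc(Oc2ccc(/C=C/c3ccccn3)cc2)ccn1` gives 30200 nM in this assay. Compound 2 `O=C(Nc1ccc(Cl)cc1)c1cc(Oc2ccc(/C=C/c3ccccn3)cc2)ccn1`, which carries chloro in place of hydrogen on an aromatic carbon, gives 31300 nM in this assay; the step of a 1.0-fold higher number from compound 1 to compound 2 (0.02 log units; within the scatter) shows that this change made no difference beyond the scatter. Compound 3 `O=C(Nc1ccccc1)c1cc(Oc2ccc(/C=C/c3ccncc3)cc2)ccn1` carries pyridin-4-yl in place of pyridin-2-yl on a double-bonded chain carbon bound to a double-bonded chain carbon. For compound 3 only a limit is known in this assay, namely > 100000 nM, which is the limit of > 100000 nM in this assay, at which 1 of the 3 values shown sits, and not a number. The step of an at least 3.3-fold higher number from compound 1 to compound 3 (0.51 log units; beyond the scatter) is accordingly itself a limit, marking a loss of at least modest size.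

Compound 4 `O=C(NCc1ccc(F)cc1)c1cc(Oc2ccc(/C=C/c3ccncc3)cc2)ccn1` differs from compound 3 at the amide-type nitrogen: 4-fluorobenzyl in place of phenyl on an amide-type nitrogen. Neither measured step touches this nitrogen, so none bears directly on the change. For the measured compounds named here, the only step on that side of the molecule, a 1.0-fold higher number from compound 1 to compound 2 (0.02 log units; within the scatter), stayed within the scatter, and compound 3 already sits at the limit. The expected step that the limit leaves unreadable from compound 3 to compound 4 is therefore none beyond the scatter, in neither direction. Compound 4 is estimated at 150000 nM, within 40000 nM to 600000 nM, and will most likely again be reported only as a limit.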

Compound 4, half-maximal inhibitory concentration: 37200 nM
The estimate for compound 4 lay 4.0-fold (0.61 log units) above the measured number; measured number below the stated range.
By their numbers in this assay, from the lowest: compounds 1, 2 and 4 (each within the scatter of the next). At a limit, above all of these: compound 3.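

Replacing phenyl with 4-fluorobenzyl on the amide-type nitrogen gives an at least 2.6-fold lower number from compound 3 to compound 4 (0.42 log units; beyond the scatter) in this assay. The group on this nitrogen can therefore change the read-out, which the chloro change on the phenyl ring, a 1.0-fold higher number from compound 1 to compound 2 (0.02 log units; within the scatter), gave no sign of. This holds for a pair carrying pyridin-4-yl, and its true size remains unknown because compound 3 has no measured number, only a limit: the limit of > 100000 nM in this assay, at which 1 of the 4 values shown sits.

The enlarged group brings in both a benzyl link and a fluorine, so this single pair cannot say which of the two matters; unsubstituted benzyl on the same nitrogen would begin to separate them, as would a 2-phenylethyl group for the length of the link. As far as these compounds go, it also remains open whether 4-fluorobenzyl would produce a similar step on the pyridin-2-yl version of the core, where the starting compound has a real number rather than a limit and the full size of the step could be read.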